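This account rests on a few compounds, and the source may have more. Where it says the series, first, only, none or still open, it means among the compounds named here.

In a functional assay on HepG2 cells (Homo sapiens) for antiproliferative activity, read by MTT assay, with a stated time of 72 h (a higher number here means a weaker inhibitor, a lower number a stronger inhibitor), compound 1 `NC1=NC2(CCSCC2)N(OCCCOc2ccc(Cl)c(Cl)c2)C(N)=N1` gives 70 nM as the lowest of the three measured numbers, which makes it the strongest inhibitor so far. Compound 3 `NC1=NC2(CCOCC2)N(OCCCOc2cccc(Cl)c2)C(N)=N1` reads 150 nM and compound 2 `NC1=NC2(CCOCC2)N(OCCCOc2cccc(Br)c2)C(N)=N1` reads 320 nM on a core that differs from the core of compound 1. Compound 4 `NC1=NC2(CCSCC2)N(OCCCOc2cccc(Br)c2)C(N)=N1` keeps the core of compound 1 and differs from it by a single swap: 3-bromophenyl in place of 3,4-dichlorophenyl on an oxygen on a saturated carbon and nothing else changes.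

Going by the values given here, only one measured step bears on this swap, namely a 2.1-fold lower number from compound 2 to compound 3 (0.33 log units; beyond the scatter) for chloro in place of bromo on an aromatic carbon. Read in reverse, that modest step links a bromo to a higher number than a chloro, although it was seen on the other core. Among the compounds with values here, no measured pair shows what losing a chlorine alone does, so that part of the swap stays open. On this evidence, a modest rise beyond the scatter is expected, and a 2.3-fold higher number from compound 1 to compound 4 (0.36 log units; beyond the scatter) is the estimated step towards a weaker inhibitor. For compound 4 the estimated value in this assay is 160 nM with an expected range from 70 nM to 400 nM for repeated measurements.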

Compound 4, half-maximal inhibitory concentration: 90 nM
The estimate for compound 4 lay 1.8-fold (0.25 log units) above the measured number; measured number inside the range.
By their numbers in this assay, from the lowest: compounds 1, 4 and 3 (each within the scatter of the next, the first and the last beyond it); then compound 2.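

In this assay, the swap on the oxygen on a saturated carbon gives a 1.3-fold higher number from compound 1 to compound 4 (0.11 log units; within the scatter), so on the core of compound 1 the 3-bromophenyl and 3,4-dichlorophenyl groups cannot be told apart. Going by these compounds alone, until now, the only change on the aromatic ring with a measured result was the one on the other core, a 2.1-fold lower number from compound 2 to compound 3 (0.33 log units; beyond the scatter), which lay beyond the scatter. The new pair shows that, on the core of compound 1, this position accepts a ring with one bromine as well as a ring with two chlorines, although the number and the kind of halogen both change. Nothing measured here gives a reason for this result.

Since both halogen features change at once, the compounds shown leave open what the bromine, each chlorine and the number of halogens contribute separately on the core of compound 1. Going by these compounds, whether this position needs a halogen at all also remains open, and a plain phenyl ring, or one carrying a methoxy group or a nitrile, would test that.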